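The source may hold more compounds than are shown below. What is called first, only, known or untested is meant among the compounds shown, and "the series" means these compounds.

Measured compounds:
Compound 1, `CCCC(O)CC(=O)O[C@H](CC=C(C)C)C1=CC(=O)c2c(O)ccc(O)c2C1=O` — in a functional assay on DU-145 cells (Homo sapiens) for cytotoxicity, read by MTT assay (on this read-out higher numbers stand for weaker inhibition and lower numbers for stronger inhibition), compound 1 gives > 100000 nM, which is a limit of the assay rather than a number.
Compound 2, `CCCCC(CC(=O)O[C@H](CC=C(C)C)C1=CC(=O)c2c(O)ccc(O)c2C1=O)OC(C)=O` — in this assay compound 2 gives 67700 nM.

Going by the values given here, compound 2 thus holds the only real number in this small set; the value for compound 1 is a limit. Among the compounds with values here, the single measured step, an at least 1.4-fold lower number from compound 1 to compound 2 (0.16 log units; that floor lies within the scatter), rests on the limit of > 100000 nM in this assay, at which 1 of the 2 values shown sits, and sets only a floor that stays within the scatter, so the data contain no change of clear size.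

Compound 3, `CCC(C)(O)CC(=O)O[C@H](CC=C(C)C)C1=CC(=O)c2c(O)ccc(O)c2C1=O`, differs from compound 2 in one place: 1-hydroxy-1-methylpropyl in place of 1-acetoxypentyl on a saturated chain carbon bound to a carbonyl carbon. The entering 1-hydroxy-1-methylpropyl carries one hydrogen-bond donor, as does the 1-hydroxybutyl of compound 1. Compound 1, with that donor at the same position, gave > 100000 nM, a limit. Within the data shown here, only the step from compound 1 to compound 2 bears on the present change, and it is small and bounded. On that basis compound 3 is expected to move back toward weaker inhibition, by about a 1.5-fold higher number from compound 2 to compound 3 (0.17 log units; within the scatter), with a limit again quite possible. Compound 3 is therefore estimated at 100000 nM, within a range from 40000 nM to 250000 nM.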

Compound 3, half-maximal inhibitory concentration: 16000 nM
Compound 3: the middle estimate sits 6.3-fold (0.80 log units) above what was measured; measured number outside the range, below it.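

In this assay, the position on a saturated chain carbon bound to a carbonyl carbon now shows a change beyond the scatter: replacing 1-acetoxypentyl with 1-hydroxy-1-methylpropyl gives a 4.2-fold lower number from compound 2 to compound 3 (0.63 log units; beyond the scatter), so this place in the molecule can shift the read-out by a clear amount. Carrying a hydrogen-bond donor does not by itself set the outcome, as 1-hydroxybutyl and 1-hydroxy-1-methylpropyl each carry one, yet exchanging the first for the second gives an at least 6.2-fold lower number from compound 1 to compound 3 (0.79 log units; beyond the scatter). That step gives only a minimum size and not a full one, since compound 1 has no true number, only a limit: the limit of > 100000 nM in this assay, at which 1 of the 3 values shown sits.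

The compounds shown do not separate the contribution of the hydroxyl from that of the methyl branch on the same carbon, and they give no true number for compound 1. On these data alone, how an amine, a carboxylic acid or a longer branched chain bearing a hydroxyl would behave at this place also remains open, so whether any of them would give stronger inhibition than compound 3, which gives 16000 nM, cannot be told.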